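This account rests on a few compounds, and the source may have more. Where it says the series, first, only, none or still open, it means among the compounds named here.

Series notes. Compound 1 `COC(CC(C)C(O)/C=C/C=C/CNC(=O)C(C)(C)C(O)/C(C)=C\C=C/C=C/C(C)=C(\C)[N+](=O)[O-])C1(O)C(C)C(=O)N(C)C12C(=O)OC2C` and compound 2 `CO[C@@H](C[C@@H](C)[C@@H](O)/C=C/C=C/CNC(=O)C(C)(C)[C@H](O)/C(C)=C/C=C/C=C/C(C)=C(\C)[N+](=O)[O-])[C@]1(O)[C@@H](C)C(=O)N(C)[C@@]12COC2=O` share one core. In a functional assay on K562 cells (Homo sapiens) for cytotoxicity (a lower number here means a stronger inhibitor, a higher number a weaker inhibitor), compound 1 gives > 100000 nM, which is a limit of the assay rather than a number. In this assay compound 2 likewise gives > 100000 nM, again a limit and not a number. Compound 2 therefore stands at the upper edge of what this assay can report, and the whole of the evidence is the limit of > 100000 nM in this assay, at which 2 of the 2 values shown sit. Compound 3 `CO[C@@H](C[C@@H](C)[C@@H](O)/C=C/C=C/CNC(=O)C(C)(C)[C@H](O)/C(C)=C/C=C/C=C/C(C)=C(\C)[N+](=O)[O-])[C@]1(O)[C@@H](C)C(=O)N(C)[C@]12C(=O)O[C@@H]2C` is compound 2 with methyl in place of hydrogen on a saturated ring carbon. For the measured compounds named here, no measured step bears on this change; the two limits say nothing about size or direction, so no shift beyond the scatter is expected, and the step is estimated as a step that the limit leaves unreadable from compound 2 to compound 3. Compound 3 is thus expected to give about 150000 nM in this assay, within 30000 nM to 500000 nM, most likely reported once more only as a limit.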

Compound 3, half-maximal inhibitory concentration: > 100000 nM
Compound 3 ended at the assay's limit; the forecaster's own chance of this, stated with the estimate: 85%; the middle value does not contradict the limit.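

In this assay, for the compounds shown here, compound 3 sits at the same limit as compound 1 and compound 2, so no step to compound 3 can be read from either. The compounds shown leave open whether methyl in place of hydrogen, or the drawn configuration, changes the cytotoxicity at all.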